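The source may hold more compounds than are shown below. What is called first, only, known or untested is meant among the compounds shown, and "the series" means these compounds.

Measured so far in an ADME assay on C8166 cells (Homo sapiens) for cytotoxicity, read by colorimetric assay and MTT assay; a higher number here means that more compound is tolerated, a lower number that less compound is tolerated:

compound 1, `Cc1ccc(C)c(C(=O)c2c(OCC(=O)Nc3ccc(S(N)(=O)=O)cc3C)ccc3ccccc23)c1`: 47500 nM
compound 2, `Cc1ccc(C(=O)c2c(OCC(=O)Nc3ccc(S(N)(=O)=O)cc3C)ccc3ccccc23)cc1C`: 33000 nM

Compound 1 stands highest of these two numbers, but its only neighbour is compound 2, and the step of a 1.4-fold lower number from compound 1 to compound 2 (0.16 log units; within the scatter) lies within the scatter, so the two cannot be told apart on the numbers shown; that step swaps one dimethylphenyl for another on the carbonyl carbon.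

The compound now in question is compound 3, `Cc1ccc(C)c(C(=O)c2c(OCC(=O)Nc3ccc(S(N)(=O)=O)cc3C)ccc3cc(Br)ccc23)c1`, still to be measured in this assay. It differs from compound 1 in one place: bromo in place of hydrogen on an aromatic carbon, the carbon being part of a six-membered aromatic ring of carbon only within a fused system of two rings, meta to a fused ring and para to a fused ring. Going by the values given here, no measured step touches that ring; the single step on record, a 1.4-fold lower number from compound 1 to compound 2 (0.16 log units; within the scatter), concerns a different part of the molecule and was itself within the scatter. With nothing pointing either way, compound 3 is expected to stay close to compound 1, with a step of about a 1.2-fold lower number from compound 1 to compound 3 (0.07 log units; within the scatter), not beyond the scatter. The estimate for compound 3 is 40000 nM, with a range from 15000 nM to 100000 nM.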

Compound 3, half-maximal cytotoxic concentration: 14000 nM
For compound 3 the middle estimate is 2.9-fold (0.46 log units) above the measured one; the whole stated range lies above it.
By their numbers in this assay, from the lowest: compound 3; then compounds 2 and 1 (each within the scatter of the next).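

This result shows that the carbon on the fused ring system, meta to a fused ring and para to a fused ring, is not a silent place in this assay: the step is a 3.4-fold lower number from compound 1 to compound 3 (0.53 log units; beyond the scatter) and it lies beyond the scatter, so less of the brominated compound is tolerated by the cells. The earlier pair could not show this, since the swap of one dimethylphenyl for another on the carbonyl carbon gave only a 1.4-fold lower number from compound 1 to compound 2 (0.16 log units; within the scatter) and stayed within the scatter, whereas here the entry of a single bromine atom, a group with no ring and no hydrogen-bond donors or acceptors, is enough to move the number measurably. Nothing presented here explains why this one atom has that result.

As far as these compounds go, whether the change belongs to bromo itself or would follow any group on this carbon stays open, as a fluoro, a methoxy or an amine there might give quite different numbers. Also open, from the compounds shown here alone, is whether bromo would give a similar step on the 3,4-dimethylphenyl compound, compound 2, or only with the 2,5-dimethylphenyl group of compound 1.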